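This account rests on a few compounds, and the source may have more. Where it says the series, first, only, none or still open, it means among the compounds named here.

Measured so far:
- compound 1, `Cc1ccc(-c2nc(N)c3cc(-c4ccccc4)sc3n2)o1`: 520 nM
- compound 2, `Nc1nc(-c2cnco2)nc2sc(Cc3ccccc3)cc12`: 106 nM
- compound 3, `Cc1csc(-c2nc(N)c3cc(C(C)c4ccccc4)sc3n2)n1`: 1420 nM

All three were run in a functional assay on CHO-K1 cells for antagonist activity at adenosine receptor A1 (Homo sapiens), read by a beta-galactosidase reporter and cAMP accumulation, with stated times of 15 min and 6 h; a lower number here means a stronger inhibitor, a higher number a weaker inhibitor. Compound 2 gives the lowest number of the three; the gap from compound 2 to compound 1 and the larger gap from compound 2 to compound 3 both lie beyond the usual scatter, so compound 2 is the strongest inhibitor in this set. No pair of these compounds differs in one place only, so no single structural step can be read from the measured values; compound 1 and compound 3 each carry a different group on the aromatic carbon between two ring nitrogen atoms and a different substituent on the thiophene part of the shared core.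

The next compound, compound 4, `N#Cc1cncc(-c2nc(N)c3cc(Cc4ccccc4)sc3n2)c1`, keeps the benzyl substituent of compound 2 and changes only the group on the shared core: 5-cyanopyridin-3-yl in place of 1,3-oxazol-5-yl on an aromatic carbon. Among the measured compounds shown here, with no measured step of this kind available, the expectation rests on compound 2 alone. A small to moderate rise in the number is expected, near the edge of the scatter; the expected step is a 2.4-fold higher number from compound 2 to compound 4 (0.37 log units; beyond the scatter). Compound 4 is estimated at 250 nM in this assay, with a range from 60 nM to 1000 nM.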

Compound 4, inhibition constant: 1160 nM
Beside the measured number, compound 4's estimate is 4.6-fold (0.67 log units) below it; measured number above the stated range.
By their numbers in this assay, from the lowest: compound 2; then compound 1; then compounds 4 and 3 (each within the scatter of the next).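

In this assay, among the compounds shown here, with the benzyl substituent held fixed, 5-cyanopyridin-3-yl in place of 1,3-oxazol-5-yl gives an 11-fold higher number from compound 2 to compound 4 (1.04 log units; beyond the scatter) as a large step, the first evidence that the group on the aromatic carbon between two ring nitrogen atoms can by itself shift the number well beyond the scatter. The change replaces a five-membered aromatic ring with 2 hetero atoms by a six-membered aromatic ring with 1 hetero atom and a nitrile, and the hydrogen-bond acceptor count is the same on both sides, so the step does not go with a change in that count. No measurement at hand accounts for the step, and ring size, the hetero atoms and the nitrile all change together in this single pair.

The compounds shown leave open whether the step follows the nitrile or the six-membered ring, a question that unsubstituted pyridin-3-yl on the same benzyl compound would address. They also leave open how a small amine or a carboxylic acid would fare at this position, and whether the step would hold with the thiophene substituents of compound 1 and compound 3.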